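Aryl piperazine variation in the T-type channel series

The source may hold more compounds than are shown below. What is called first, only, known or untested is meant among the compounds shown, and "the series" means these compounds.

Compound 1 `CCCc1nc(-c2ccccc2)c(CNCCCN2CCN(c3cccc(F)c3)CC2)o1` and compound 2 `CCCc1nc(-c2ccccc2)c(CNCCCN2CCN(c3ccc(C(F)(F)F)cc3)CC2)o1` share the same core and differ only in the aryl group on the amine nitrogen in the ring. In an assay on HEK293 cells for inhibition of Voltage-dependent T-type calcium channel subunit alpha-1G (Homo sapiens), read by fluorescence, tested at 10 uM (on this read-out higher numbers stand for more inhibition at the one concentration tested (going by the name of the read-out) and lower numbers for less inhibition), compound 1 gives 68.9%, whereas compound 2 gives 51.6%; a number 17.3 percentage points lower from compound 1 to compound 2 (beyond the scatter). Going by the values given here, compound 2 therefore stands lowest of the two numbers measured so far, with compound 1 as its nearest neighbour.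

Compound 3 `CCCc1nc(-c2ccccc2)c(CNCCCN2CCN(c3ccccc3)CC2)o1` is not yet measured. It differs from compound 2 by hydrogen in place of trifluoromethyl on an aromatic carbon, or, cut one bond further out, 4-(trifluoromethyl)phenyl to phenyl. Among the compounds with values here, the only step at hand, a number 17.3 percentage points lower from compound 1 to compound 2 (beyond the scatter), bears on it indirectly: it shows that exchanging the aryl group on this nitrogen moves the read-out by a modest amount and that 4-(trifluoromethyl)phenyl sits at the lower end. Within the data shown here, removing the trifluoromethyl is expected to move compound 3 back toward compound 1, by a number 8.4 percentage points higher from compound 2 to compound 3 (within the scatter); the size is uncertain, as only one step is known. Compound 3 is thus estimated at 60%, within 45% to 75%.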

Compound 3, a percentage reported as inhibition, at one concentration (the size of the read-out at that concentration, not a potency): 43.7%
Beside the measured number, compound 3's estimate is 16.3 percentage points above it; the measured number lies below the stated range.
By their numbers in this assay, from the lowest: compounds 3 and 2 (each within the scatter of the next); then compound 1.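

Removing the trifluoromethyl gives no separable change in this assay: the step is a number 7.9 percentage points lower from compound 2 to compound 3 (within the scatter) and compounds 2 and 3 cannot be told apart on this read-out. The fluoro is different, since the step is a number 25.2 percentage points lower from compound 1 to compound 3 (beyond the scatter) when hydrogen takes its place on the aromatic carbon. Among these three compounds, then, only the fluoro replacement gives a step beyond the scatter, and the plain phenyl of compound 3 does not return the read-out to that of compound 1. Nothing available on these compounds gives a reason for either step.

The fluoro and the trifluoromethyl sit at different places on the ring, so the effect of the group and that of its place remain unseparated. Going by these compounds, whether a chloro or a methoxy group at either place would match the fluoro remains open.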